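A few compounds are considered here, and "the series" means these few. Any claim that something is new, unique, unknown or untested is made for them only; others in the source may bear on it.

Working notes on the series.

Among the measured compounds shown here, compound 2 `O=C(/C=C/c1cccc(NS(=O)(=O)c2ccccc2Cl)c1)c1nc2ccccc2[nH]1` gives 4790 nM in a functional assay on 143B cells (Homo sapiens) for antiproliferative activity, read by MTT assay, with a stated time of 48 h (a lower number here means a stronger inhibitor, a higher number a weaker inhibitor), the higher of the two numbers so far; its nearest neighbour is compound 1 `Cc1cc(C)cc(C(=O)Nc2cccc(/C=C/C(=O)c3nc4ccccc4[nH]3)c2)c1`, which in this assay gives 4020 nM, and the one step that connects them, a 1.2-fold higher number from compound 1 to compound 2 (0.08 log units; within the scatter), is within the scatter. That step exchanges the whole group on the ring nitrogen and barely moves the number.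

Compound 3 `Cc1ccccc1S(=O)(=O)Nc1cccc(/C=C/C(=O)c2nc3ccccc3[nH]2)c1` differs from compound 2 by methyl in place of chloro on an aromatic carbon. For the measured compounds named here, no measured step bears directly on this kind of exchange: the only step available, from compound 1 to compound 2, replaces one large group with another and stays within the scatter, so nothing so far suggests that a change on this ring alters the read-out much. For the step from compound 2 to compound 3 no shift beyond the scatter in this assay is therefore expected, in either direction.

Compound 3 is accordingly estimated at 4500 nM in this assay, with a range of 2000 nM to 10000 nM, that is an expected 1.1-fold lower number from compound 2 to compound 3 (0.03 log units; within the scatter).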

Compound 3, half-maximal inhibitory concentration: 4060 nM
Beside the measured number, compound 3's estimate is 1.1-fold (0.04 log units) above it; measured number inside the range.
By their numbers in this assay, from the lowest: compounds 1, 3 and 2 (each within the scatter of the next).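

In this assay, among the compounds shown here, the first direct reading at this position comes from methyl in place of chloro on an aromatic carbon ortho to a large group, which gives a 1.2-fold lower number from compound 2 to compound 3 (0.07 log units; within the scatter), so the exchange of 2-chlorophenyl for 2-methylphenyl leaves the number unchanged within the scatter. The other new step, (2-methylphenyl)sulfonyl in place of (3,5-dimethylphenyl)carbonyl on the nitrogen, gives a 1.0-fold higher number from compound 1 to compound 3 (0.00 log units; within the scatter), and with this second exchange of the whole group on that nitrogen, compound 1, compound 2 and compound 3 all stand within the scatter of one another. Nothing available explains why either exchange leaves the number where it is.

The compounds shown carry only chloro and methyl at this position, so they leave open whether an amine, a carboxylic acid, a methoxy group or a longer chain there would shift the number beyond the scatter. They also leave open whether any group on the sulfonyl-bearing ring matters at all, as a plain phenyl ring on the same sulfonyl would be needed to read the position against an unsubstituted carbon.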